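Piperazine substituent survey on a shared benzamide core

This account rests on a few compounds, and the source may have more. Where it says the series, first, only, none or still open, it means among the compounds named here.

Compound 2 `Nc1ccccc1NC(=O)c1ccc(CSC(=S)N2CCN(c3cnccn3)CC2)cc1` stands highest of the two measured numbers: in a functional assay on MGC-803 cells (Homo sapiens) for antiproliferative activity, read by CCK-8 assay, with a stated time of 72 h, tested at 2 uM (on this read-out higher numbers stand for a stronger effect at the one concentration tested and lower numbers for a weaker effect), compound 2 gives 27.1%, while compound 1 `Nc1ccccc1NC(=O)c1ccc(CSC(=S)N2CCN(C(c3ccccc3)c3ccccc3)CC2)cc1` gives 9.8%, a gap beyond the scatter. Compound 3 `Nc1ccccc1NC(=O)c1ccc(CSC(=S)N2CCN(Cc3ccccc3)CC2)cc1` is not yet measured; it differs from compound 2 by benzyl in place of pyrazin-2-yl on an amine nitrogen in a ring. Among the compounds with values here, no step between measured compounds is known for this change, so the expected direction rests only on compound 1 with its 9.8%, which carries an aryl group on a saturated carbon at the same ring nitrogen. A downward step is expected, of size a number 12.1 percentage points lower from compound 2 to compound 3 (beyond the scatter). For compound 3 the estimate is 15%, within 5% to 28%.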

Compound 3, a percentage reported as inhibition, at one concentration (the size of the read-out at that concentration, not a potency): 18.1%
For compound 3 the middle estimate is 3.1 percentage points below the measured one; measured number inside the range.
By their numbers in this assay, from the lowest: compounds 1, 3 and 2 (each within the scatter of the next, the first and the last beyond it).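

Replacing pyrazin-2-yl with benzyl on the ring nitrogen gives a number 9 percentage points lower from compound 2 to compound 3 (within the scatter) in this assay, so this change does not separate the two groups. Hydrogen in place of phenyl on the saturated chain carbon gives a number 8.3 percentage points higher from compound 1 to compound 3 (within the scatter) and, taken alone, does not separate compound 1 from compound 3 either. No measurement shown accounts for these numbers.

Still open, on these data alone, is how a phenyl or pyridin-2-yl group placed directly on the ring nitrogen would read out. A longer chain carrying the phenyl ring also remains untested in the compounds shown here.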